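Shortening the Ester Chain of Compound 1

A few compounds are considered here, and "the series" means these few. Any claim that something is new, unique, unknown or untested is made for them only; others in the source may bear on it.

Compound 1, `CCOC(=O)C1=C(C)N(c2ccccc2)C=CC1c1ccccc1`, carries an ethyl ester on its core. In a functional assay, tested at 200 ug/mL (on this read-out lower numbers stand for a stronger effect and higher numbers for a weaker effect at the one concentration tested), compound 1 gives -29.3%, the highest of the three numbers measured. Its two neighbours differ from it only on an aromatic carbon: compound 2, `CCOC(=O)C1=C(C)N(c2ccc(C)cc2)C=CC1c1ccccc1`, gives -32.7%, and compound 3, `CCOC(=O)C1=C(C)N(c2ccc(Br)cc2)C=CC1c1ccccc1`, gives -35.7%. The steps of a number 3.4 percentage points lower from compound 1 to compound 2 (within the scatter), a number 6.4 percentage points lower from compound 1 to compound 3 (within the scatter) and a number 3 percentage points lower from compound 2 to compound 3 (within the scatter) all lie within the scatter. Compound 4, `COC(=O)C1=C(C)N(c2ccccc2)C=CC1c1ccccc1`, differs from compound 1 elsewhere: hydrogen in place of methyl on a saturated chain carbon bound to an oxygen next to a carbonyl group. Among the compounds with values here, none of the measured steps touches this part of the molecule, so no measured step bears on it directly. As every change seen so far left the read-out within the scatter, compound 4 is expected to show a step of a number 0.3 percentage points higher from compound 1 to compound 4 (within the scatter), not beyond the scatter. Compound 4 is therefore estimated at -29%, with a range from -41% to -17%.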

Compound 4, a percentage reported as activity, at one concentration (the size of the read-out at that concentration, not a potency): -23%
Compound 4: the middle estimate sits 6 percentage points below what was measured; low and high end bracket the measured number.
By their numbers in this assay, from the lowest: compounds 3, 2, 1 and 4 (each within the scatter of the next, the first and the last beyond it).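

Swapping ethoxycarbonyl for methoxycarbonyl gives the first reading at the ester end of the molecule: in this assay the result is a number 6.3 percentage points higher from compound 1 to compound 4 (within the scatter) and no more than that. Shortening the chain by this one methyl therefore stays within the scatter, as the changes on the aromatic carbon did. No available evidence explains this result.

As far as these compounds go, whether a longer chain such as propyl or butyl would also stay within the scatter remains open. So does the outcome of replacing the ester with a carboxylic acid or an amide.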